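Flipping the Sulfur Stereocentre in a Cytotoxicity Test

The source may hold more compounds than are shown below. What is called first, only, known or untested is meant among the compounds shown, and "the series" means these compounds.

- compound 1 `COc1ccc(-c2ccc(O[C@@H]3COc4nc([N+](=O)[O-])cn4C3)nc2)cn1`: > 10 ug/mL (a limit of the assay, not a number)
- compound 2 `O=[N+]([O-])c1cn2c(n1)[S@+]([O-])C[C@H](OCc1ccc(OC(F)(F)F)cc1)C2`: > 10 ug/mL (a limit of the assay, not a number)

Both entries come from an ADME assay on L929 cells (Mus musculus) for cytotoxicity; on this read-out lower numbers stand for stronger inhibition and higher numbers for weaker inhibition. The record so far is the limit of > 10 ug/mL in this assay, at which 2 of the 2 values shown sit. The position of compound 2 is therefore known only as a limit, with no exact number behind it.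

Compound 3 `O=[N+]([O-])c1cn2c(n1)[S@@+]([O-])C[C@H](OCc1ccc(OC(F)(F)F)cc1)C2` has not yet been measured, and it is related to compound 2 by a single change: the two compounds have the same atoms and bonds and differ only in configuration as drawn: 1 of 2 stereo elements differ; a stereocentre at a sulfur is drawn R in compound 2 and S in compound 3. For the measured compounds named here, no measured pair shows what such a change does in this assay, so no shift in either direction beyond the usual scatter is expected. The expected step that the limit leaves unreadable from compound 2 to compound 3 is accordingly small. This expectation rests on compound 2, whose limit is > 10 ug/mL. The estimated value for compound 3 is 15 ug/mL, with an expected range of 8 ug/mL to 40 ug/mL.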

Compound 3, half-maximal inhibitory concentration: > 10 ug/mL
Compound 3: no number, only a limit; the forecaster's own chance of this, stated with the estimate: 85%; the middle value lies beyond the limit too.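

For the compounds shown here, compound 2 and compound 3 each give only a limit in this assay, not a number, so no step between them can be read. The compounds shown leave open how far past that limit each one lies, and whether the configuration at the sulfur matters in this assay at all.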